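This account rests on a few compounds, and the source may have more. Where it says the series, first, only, none or still open, it means among the compounds named here.

Working notes on the series. Compound 1 `Cc1cc(N2CCCC2)cn2c(CSCCc3ccccc3)cnc12` and compound 2 `Cc1cc(-n2ccnc2)cn2c(CSCCc3ccccc3)cnc12` share a core and differ at one aromatic carbon. In an ADME assay on HEL cells (Homo sapiens) for cytotoxicity, with a stated time of 3 days (on this read-out lower numbers stand for higher toxicity in this test and higher numbers for lower toxicity in this test), compound 1 gives 20 ug/mL, and compound 2 gives 100 ug/mL. The change is a 5.0-fold higher number from compound 1 to compound 2 (0.70 log units; beyond the scatter). On these two numbers compound 2 stands highest; the nearest is compound 1, a step below it that is beyond the scatter.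

Compound 3 `Cc1cc(C#N)cn2c(CSCCc3ccccc3)cnc12` is not yet measured in this assay. It differs from compound 2 as follows: cyano in place of 1H-imidazol-1-yl on an aromatic carbon. Within the data shown here, no measured step carries a cyano group, so only the single step from compound 1 to compound 2 gives any sense of how this position responds; that step was modest and upward. Among the measured compounds shown here, with no direct precedent, a move of no more than modest size is expected, with the direction uncertain and a slight lean downward. Compound 3 is therefore estimated at 60 ug/mL, within 20 ug/mL to 150 ug/mL. This estimate means a step of a 1.7-fold lower number from compound 2 to compound 3 (0.22 log units; within the scatter).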

Compound 3, minimum cytotoxic concentration: 20 ug/mL
Compound 3: the middle estimate sits 3.0-fold (0.48 log units) above what was measured, within the range that was stated.
By their numbers in this assay, from the lowest: compounds 1 and 3 (each within the scatter of the next); then compound 2.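

In this assay, cyano in place of 1H-imidazol-1-yl gives a 5.0-fold lower number from compound 2 to compound 3 (0.70 log units; beyond the scatter), so this aromatic carbon now shows a downward step as well as the earlier upward one. Cyano in place of pyrrolidin-1-yl gives no change at the digits printed from compound 1 to compound 3 (within the scatter), so a group with no ring and a group with a ring read alike here, and among these three compounds only compound 2, with 1H-imidazol-1-yl, stands apart. Nothing at hand accounts for this pattern.

On these data alone, it remains open whether the higher number belongs to 1H-imidazol-1-yl alone or extends to other five-membered aromatic rings with two hetero atoms, such as pyrazol-1-yl. As far as these compounds go, how a carboxylic acid or an open-chain amine at this aromatic carbon would read is also open.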